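Iminoquinone bis-carbamate: expected activity of compound 3

The compounds below may be only part of what the source reports. "The series", "measured", "known", "first", "only" and "open" are said of these compounds alone.

Measured so far:
compound 1 `CNC(=O)OCc1c2c(n(C)c1COC(=O)NC)C(=O)C(C)=C(OC)C2=O`: < 0.03 ug/mL (a limit)
compound 2 `CNC(=O)OCc1c2c(n(C)c1COC(C)=O)C(O)=C(C)C(=N)C2=O`: > 31 ug/mL (a limit)

In a functional assay on B16-F10 cells (Mus musculus) for antiproliferative activity (a higher number here means a weaker inhibitor, a lower number a stronger inhibitor), compound 1 sits at the lower limit of the read-out, < 0.03 ug/mL. In this assay compound 2 gives only a limit, > 31 ug/mL, consistent with the limit of > 31 ug/mL in this assay, at which 1 of the 2 values shown sits. Compound 3 `CNC(=O)OCc1c2c(n(C)c1COC(=O)NC)C(O)=C(C)C(=N)C2=O` differs from compound 2 by methylamino in place of methyl on a carbonyl carbon. Within the data shown here, no step between measured compounds is available; the two values merely place compound 1 and compound 2 at opposite limits of this assay. Starting from compound 2 at the limit of > 31 ug/mL in this assay, at which 1 of the 2 values shown sits, the expected step is a moderate shift toward stronger inhibition, an at least 2.0-fold lower number from compound 2 to compound 3 (0.31 log units; beyond the scatter). Compound 3 is estimated at 15 ug/mL, between 2 ug/mL and 60 ug/mL.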

Compound 3, half-maximal inhibitory concentration: 13.3 ug/mL
Compound 3: the middle estimate sits 1.1-fold (0.05 log units) above what was measured; measured number inside the range.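

In this assay, replacing acetoxymethyl with ((methylcarbamoyl)oxy)methyl gives an at least 2.3-fold lower number from compound 2 to compound 3 (0.36 log units; beyond the scatter). This single change therefore moves the read-out on the core of compound 2 and gives compound 3 a number that can be read. The full size of the step cannot be read, since compound 2 carries only a limit: the limit of > 31 ug/mL in this assay, at which 1 of the 3 values shown sits.

Whether this depends on methylamino itself stays open, as no amino, dimethylamino or ethylamino group on the same carbonyl carbon is shown. Also open, as far as these compounds go, is whether the same change carries equal weight on the core of compound 1.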